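The source may report more compounds than this note shows. Statements on the series, on what has been measured and on what is new or still open speak of the compounds shown alone.

Working notes on the shared core of compound 1 `O=C(Nc1ccc(Cl)cc1)Nc1nn(-c2ccccc2)c(=O)c2ccccc12`. In an assay on CHO cells for displacement of a labelled ligand from adenosine receptor A1 (Homo sapiens), tested at 10 uM (on this read-out higher numbers stand for more inhibition at the one concentration tested (going by the name of the read-out) and lower numbers for less inhibition), compound 1 gives 10%. Compound 2 `O=C(Nc1nn(-c2ccccc2)c(=O)c2ccccc12)c1ccco1` gives 23% in this assay, and compound 3 `Cc1ccccc1NC(=O)Nc1nn(-c2ccccc2)c(=O)c2ccccc12` gives 20%. Compound 1 stands lowest of the three numbers: the step of a number 10 percentage points higher from compound 1 to compound 3 (within the scatter) stays within the scatter, the step of a number 13 percentage points higher from compound 1 to compound 2 (beyond the scatter) lies beyond it, and the step of a number 3 percentage points lower from compound 2 to compound 3 (within the scatter) is again within the scatter.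

Compound 4 `O=C(Nc1nn(-c2ccccc2)c(=O)c2ccccc12)c1ccc(Cl)cc1` has not been measured. Relative to compound 1 the change is 4-chlorophenyl in place of (4-chlorophenyl)amino on a carbonyl carbon. The closest comparison is the step from compound 1 to compound 2, where the same (4-chlorophenyl)amino left the carbonyl carbon and furan-2-yl entered, giving a number 13 percentage points higher from compound 1 to compound 2 (beyond the scatter), a modest rise. The other two steps, a number 10 percentage points higher from compound 1 to compound 3 (within the scatter) and a number 3 percentage points lower from compound 2 to compound 3 (within the scatter), show that exchanging the group on the amide-type nitrogen or on the carbonyl carbon among these three compounds otherwise leaves the number within the scatter. For compound 4 a small rise in this assay is therefore expected, of about the size seen with compound 2, or none beyond the scatter. The expected step is a number 8 percentage points higher from compound 1 to compound 4 (within the scatter). Compound 4 is estimated at 18%, with a range from 5% to 35%.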

Compound 4, a percentage reported as inhibition, at one concentration (the size of the read-out at that concentration, not a potency): 26%
Estimate against measurement, compound 4: 8 percentage points below, within the range that was stated.
By their numbers in this assay, from the lowest: compounds 1, 3, 2 and 4 (each within the scatter of the next, the first and the last beyond it).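

On the carbonyl carbon, 4-chlorophenyl in place of (4-chlorophenyl)amino gives a number 16 percentage points higher from compound 1 to compound 4 (beyond the scatter) in this assay, so the same chlorinated ring gives a different number once the nitrogen and its hydrogen-bond donor leave, and the rise seen with compound 2 is not confined to furan-2-yl: the step of a number 3 percentage points higher from compound 2 to compound 4 (within the scatter) does not separate the two groups. The nitrogen alone does not set the number, however, since compound 3 keeps an amide-type nitrogen at this place and the step of a number 6 percentage points higher from compound 3 to compound 4 (within the scatter) does not separate it from compound 4, so compound 3 goes against any simple rule that loss of that nitrogen raises the number. No measurement on these compounds offers an explanation for the rise.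

Still open, on these data alone, is whether the change holds beyond these aryl and furan-2-yl groups, for instance with a saturated amine such as piperidine, a short alkyl chain or a carboxylic acid on the carbonyl carbon. Every number here comes from a single concentration, so how strong the effect of these compounds would be at other concentrations and any order among compounds 2, 3 and 4 also remain open.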